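Adding hydroxy to the phenyl of compound 2

The compounds below may be only part of what the source reports. "The series", "measured", "known", "first", "only" and "open" are said of these compounds alone.

- compound 1 `COc1ccccc1-c1ccc2ncn(-c3cc(OC)c(OC)c(OC)c3)c2c1`: 5050 nM
- compound 2 `COc1cc(-n2cnc3ccc(-c4ccccc4)cc32)cc(OC)c1OC`: 290 nM

In a functional assay on SGC-7901 cells (Homo sapiens) for antiproliferative activity, read by MTT assay, with a stated time of 72 h (a lower number here means a stronger inhibitor, a higher number a weaker inhibitor), compound 2 has the lower of the two numbers, 290 nM. Compound 3 `COc1cc(-n2cnc3ccc(-c4cccc(O)c4)cc32)cc(OC)c1OC` differs from it by hydroxy in place of hydrogen on an aromatic carbon, which is hydroxy in place of hydrogen on an aromatic carbon, turning phenyl to 3-hydroxyphenyl. Going by the values given here, the only measured step, a 17-fold lower number from compound 1 to compound 2 (1.24 log units; beyond the scatter), is large, but it involves methoxy rather than hydroxy, so it offers weak guidance on size or direction. No step beyond the scatter is therefore expected in this assay, though with wide uncertainty. The expected change is a 1.2-fold higher number from compound 2 to compound 3 (0.08 log units; within the scatter). For compound 3 the estimate is 350 nM, with an expected range of 80 nM to 1500 nM.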

Compound 3, half-maximal inhibitory concentration: 53 nM
Beside the measured number, compound 3's estimate is 6.6-fold (0.82 log units) above it; the measured number lies below the stated range.
By their numbers in this assay, from the lowest: compound 3; then compound 2; then compound 1.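

In this assay the change from phenyl to 3-hydroxyphenyl gives a 5.5-fold lower number from compound 2 to compound 3 (0.74 log units; beyond the scatter) and so shows that a substituent on this ring can lower the number, whereas the only earlier one, the methoxy of compound 1, went with a higher number. Replacing 2-methoxyphenyl with 3-hydroxyphenyl gives a 95-fold lower number from compound 1 to compound 3 (1.98 log units; beyond the scatter) but changes both the group and its place on the ring. No measurement shown accounts for the drop.

On these data alone, whether the gain belongs to hydroxy itself or to its place remains open. Methoxy, an amine or a carboxylic acid at this same place would help separate the two.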